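Amide swap in a pyrazole series: what lipophilicity to expect

The source may report more compounds than this note shows. Statements on the series, on what has been measured and on what is new or still open speak of the compounds shown alone.

Within the data shown here, in a physicochemical assay for lipophilicity, at pH 7.4 (a lower number here means a more polar compound, a higher number a more lipophilic compound), compound 2, `Cc1cc(C(=O)Nc2cccc(F)c2)nn1Cc1cc(Cl)ccc1OCc1ccccc1`, gives 2.8, the only plain number among the three measured compounds. Compound 1, `Cc1cc(C(=O)NC(C)C)nn1Cc1cc(Cl)ccc1OCc1ccccc1`, reaches only a limit of the assay, > 3.7. Compound 3, `Cc1cc(C(=O)NCc2ccccn2)nn1Cc1cc(Cl)ccc1OCc1ccccc1`, likewise reaches only a limit, > 3.7. The two measured steps that touch compound 2 are both at least modest: a number at least 0.90 log units lower from compound 1 to compound 2 (beyond the scatter), and a number at least 0.90 log units higher from compound 2 to compound 3 (beyond the scatter). Both sit against (the limit of > 3.7 in this assay, at which 2 of the 3 values shown sit), so their full size is not known.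

Compound 4, `Cc1cc(NC(=O)C2CCCO2)nn1Cc1cc(Cl)ccc1OCc1ccccc1`, differs from compound 2 in the group on the shared core: ((oxolan-2-yl)carbonyl)amino in place of (3-fluorophenyl)carbamoyl on an aromatic carbon. Among the measured compounds shown here, none of the measured steps changes the amide the same way, so they show only that swapping the group on the amide-type nitrogen moves this assay by at least a modest amount. Compound 4 is expected to come out lower than compound 2, with an estimated step of a number 0.80 log units lower from compound 2 to compound 4 (beyond the scatter). The estimate for compound 4 is 2, between 1.4 and 2.6.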

Compound 4, distribution coefficient: > 3.7
Compound 4: a limit, no number; the forecaster's own chance of this, stated with the estimate: 5%; middle value at least 1.70 log units from the limit.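

Placing ((oxolan-2-yl)carbonyl)amino in place of (3-fluorophenyl)carbamoyl on this aromatic carbon gives, in this assay, a number at least 0.90 log units higher from compound 2 to compound 4 (beyond the scatter), so this change reverses the direction of the link to the core and replaces the aromatic ring without bringing the value below that of compound 2. Compound 4 gives > 3.7, which is a limit and not a number, so its steps to compound 1 and compound 3, which also reach limits, cannot be read. Compound 2 therefore remains the only compound with a plain number, while the others stop at the same point: the limit of > 3.7 in this assay, at which 3 of the 4 values shown sit.

Going by these compounds, how far compound 1, compound 3 and compound 4 lie beyond that limit remains open. Also open, on these data alone, is whether the reversed link or the new ring accounts for the step, which a (3-fluorophenyl)carbonylamino group at this place could separate, and where a carboxylic acid here would fall.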